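A Sulfo-to-Hydroxy Swap on Two Related Cores

This account rests on a few compounds, and the source may have more. Where it says the series, first, only, none or still open, it means among the compounds named here.

Measured so far in a functional assay on HL-60 cells (Homo sapiens) for cytotoxicity, read by trypan blue exclusion, with a stated time of 48 h; a higher number here means that more compound is tolerated, a lower number that less compound is tolerated:
- compound 1 `O=C1/C(=C/c2ccccc2)CN(C(=O)CCSCCS(=O)(=O)O)C/C1=C\c1ccccc1` gives 154000 nM
- compound 2 `O=C1/C(=C/c2ccccc2)CN(C(=O)CCSCCO)C/C1=C\c1ccccc1` gives 1530 nM
- compound 3 `COc1ccc(/C=C2\CN(C(=O)CCSCCS(=O)(=O)O)C/C(=C\c3ccc(OC)cc3)C2=O)cc1` gives 91700 nM

Compound 1 and compound 2 share one core and differ only by hydroxy in place of sulfo on a saturated chain carbon, two bonds along the chain from a sulfur. That single change made a large step: a 100-fold lower number from compound 1 to compound 2 (2.00 log units; beyond the scatter). So on this core, trading the sulfo group for a hydroxy group meant that far less compound was tolerated by the cells.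

Compound 3 carries a different core, one with methoxy groups on its aromatic rings; the difference between the two cores is not broken down here. Its value in this assay lies within the scatter of compound 1, so the two cannot be told apart on the numbers alone.

Compound 4 `COc1ccc(/C=C2\CN(C(=O)CCSCCO)C/C(=C\c3ccc(OC)cc3)C2=O)cc1` is compound 3 with the same change applied: hydroxy in place of sulfo on a saturated chain carbon, two bonds along the chain from a sulfur. The place of the change is described in the same words for both pairs, so this is the same change, not merely the same kind. If the core with methoxy groups responds as the core of compound 1 did, compound 4 is expected to move by about a 92-fold lower number from compound 3 to compound 4 (1.96 log units; beyond the scatter), resting on the step from compound 1 to compound 2 and on compound 3 giving 91700 nM. Going by the values given here, on that basis compound 4 is estimated at 1000 nM in this assay, with a likely range of 300 nM to 4000 nM; the single precedent leaves room for the step to be smaller or larger.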

Compound 4, half-maximal cytotoxic concentration: 2670 nM
The estimate for compound 4 lay 2.7-fold (0.43 log units) below the measured number; the measured number falls inside the stated range.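

In this assay, the swap of sulfo for hydroxy has again lowered the number on the core with methoxy groups, and the step is large: a 34-fold lower number from compound 3 to compound 4 (1.54 log units; beyond the scatter). Set beside the earlier step, the change keeps its direction on both cores, but the two sizes cannot be treated as one shared value: the same change on two cores in this assay, a 100-fold lower number (2.00 log units; beyond the scatter) from compound 1 to compound 2 and a 34-fold lower number (1.54 log units; beyond the scatter) from compound 3 to compound 4, 2.9-fold (0.47 log units) apart, beyond the scatter of two such steps. So within this pair of cores, the step on one core was a sound guide to the direction on the other but only a rough guide to the size, and the numbers do not show why the sizes differ or whether a third core would follow the same direction.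

The compounds shown leave open how a carboxylic acid or an amine would compare with sulfo and hydroxy at the same place on a saturated chain carbon, two bonds along the chain from a sulfur, and whether a longer chain would shift the numbers. They also leave open how the same swap would behave on a core carrying fluoro or chloro groups in place of the methoxy groups.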